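Pyrimidinyl in place of isopropyl on the amide nitrogen

A few compounds are considered here, and "the series" means these few. Any claim that something is new, unique, unknown or untested is made for them only; others in the source may bear on it.

The measured compounds and their numbers:
compound 1, `Cc1ccc(OCC(=O)N(Cc2cccs2)C(C)C)cc1`, with 70 nM;
compound 2, `COc1ccc(OCC(=O)N(Cc2cccs2)c2ccn[nH]2)cc1`, with 3.7 nM;
compound 3, `Cc1ccc2oc(C(=O)N(Cc3cccs3)c3ccn[nH]3)cc2c1`, with 40 nM.

In an assay on HEK293 cells for agonist activity at transient receptor potential cation channel subfamily M member 8 (Homo sapiens), read by fluorescence and calcium flux, with a stated time of 15 min (on this read-out lower numbers stand for an effect already at smaller amounts and higher numbers for an effect only at larger amounts of compound), compound 1 gives the highest of the three numbers. Compound 3 is nearest to it, and the two values lie within the scatter of each other, so nothing can be said about their order. Compound 2 lies furthest away, with a number that is clearly lower than that of compound 1; the two differ in more than one place, so only the two values themselves can be compared.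

Compound 4, `Cc1ccc(OCC(=O)N(Cc2cccs2)c2ncccn2)cc1`, has not yet been measured. It differs from compound 1 in one place: pyrimidin-2-yl in place of isopropyl on an amide-type nitrogen. Going by the values given here, no step between measured compounds that differ in one place is known, so the size of the change can only be estimated. Because compound 2, which also carries an aromatic ring on the amide-type nitrogen, gives 3.7 nM, the step of a 4.7-fold lower number from compound 1 to compound 4 (0.67 log units; beyond the scatter) is expected to go towards a lower number, beyond the scatter. For compound 4 the estimated value is 15 nM, within a range from 3 nM to 70 nM.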

Compound 4, half-maximal effective concentration: 3700 nM
Estimate against measurement, compound 4: 250-fold (2.39 log units) below; measured number outside the range, above it.
By their numbers in this assay, from the lowest: compound 2; then compounds 3 and 1 (each within the scatter of the next); then compound 4.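

In this assay, going by these compounds alone, putting pyrimidin-2-yl in place of isopropyl on the amide-type nitrogen gives a 53-fold higher number from compound 1 to compound 4 (1.72 log units; beyond the scatter), the first step that can be read at a single place. It shows that the number responds strongly to what sits on this nitrogen, and that an aromatic ring there does not in itself bring a lower number. Nothing at hand says why the number rises with this change.

The compounds shown leave open whether the rise belongs to the aromatic ring as such or to its ring nitrogens, which a phenyl or a pyridin-2-yl group on this nitrogen would help to separate. They also leave open how a cyclopropyl or a tert-butyl group in place of isopropyl would compare with compound 1.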